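The source may hold more compounds than are shown below. What is called first, only, known or untested is meant among the compounds shown, and "the series" means these compounds.

Working notes on the series in a functional assay on HSC-2 cells (Homo sapiens) for cytotoxicity, with a stated time of 24 h; on this read-out lower numbers stand for higher toxicity in this test and higher numbers for lower toxicity in this test. Compound 1 `COc1cc(/C=C2\CCC/C(=C\c3ccccc3[N+](=O)[O-])C2=O)cc(OC)c1OC` gives 5900 nM. For the measured compounds named here, compound 2 `COc1cc(/C=C2\CCC/C(=C\c3cccc([N+](=O)[O-])c3)C2=O)cc(OC)c1OC` gives 73000 nM, the higher of the two numbers so far, which makes it the less toxic of the pair in this test.

The next compound is compound 3 `COc1cc(/C=C2\CCC/C(=C\c3ccc([N+](=O)[O-])cc3)C2=O)cc(OC)c1OC`, which has the same atoms as compound 2, joined differently: 4-nitrophenyl in place of 3-nitrophenyl on a double-bonded chain carbon bound to a double-bonded ring carbon.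

Going by the values given here, one measured step bears on this change: a 12-fold higher number from compound 1 to compound 2 (1.09 log units; beyond the scatter), with 3-nitrophenyl in place of 2-nitrophenyl at the same place. That step is large, so moving the nitro group on this ring can shift the number well beyond the scatter in this pair. It does not include 4-nitrophenyl, however, so it suggests a possible size and gives no firm direction.

With compound 2 at 73000 nM as the higher end of the range seen so far, a moderate move toward a lower number is expected, though with wide uncertainty. The expected change is a 3.7-fold lower number from compound 2 to compound 3 (0.56 log units; beyond the scatter). For compound 3 the estimated value is 20000 nM, with an expected range of 5000 nM to 80000 nM.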

Compound 3, half-maximal cytotoxic concentration: 760 nM
Estimate against measurement, compound 3: 26-fold (1.42 log units) above, outside the stated range (below it).
By their numbers in this assay, from the lowest: compound 3; then compound 1; then compound 2.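

The change to 4-nitrophenyl gives a 96-fold lower number from compound 2 to compound 3 (1.98 log units; beyond the scatter) in this assay and shows that this nitro isomer, not only 2-nitrophenyl, can sit at the low end of the range, so the number does not run in one direction across the three isomers, with 3-nitrophenyl the highest. Against 2-nitrophenyl, the same group gives a 7.8-fold lower number from compound 1 to compound 3 (0.89 log units; beyond the scatter) as well, which makes compound 3 the most toxic of the three in this test, with both of its steps beyond the scatter. Nothing measured here accounts for the differences among these isomers.

Still open, from the compounds shown here alone, is whether the low number of compound 3 depends on the nitro group itself, or whether a nitrile or an amine in place of that nitro group would give a similar value. The shared core is the same in all three compounds, so they also leave open whether this order of the isomers would hold on any other core or in cells other than those of this assay.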